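The compounds below may be only part of what the source reports. "The series", "measured", "known", "first", "only" and "open" are said of these compounds alone.

Compound 1 `Cc1cc(-c2ccco2)c(S(C)(=O)=O)cc1C(=O)N=C(N)N`: 16 nM
Compound 2 `CSc1cc(C)c(C(=O)N=C(N)N)cc1S(C)(=O)=O`: 6 nM
Compound 3 `Cc1cc(Sc2ccc(Cl)cc2)c(S(C)(=O)=O)cc1C(=O)N=C(N)N`: 19 nM

In a functional assay for inhibition of sodium/hydrogen exchanger (Oryctolagus cuniculus) (on this read-out higher numbers stand for weaker inhibition and lower numbers for stronger inhibition), compound 3 gives 19 nM, the highest of the three numbers. The step of a 1.2-fold higher number from compound 1 to compound 3 (0.07 log units; within the scatter) stays within the scatter, whereas a 3.2-fold higher number from compound 2 to compound 3 (0.50 log units; beyond the scatter) lies beyond it. Compound 4 `Cc1cc(OC(C)C)c(S(C)(=O)=O)cc1C(=O)N=C(N)N` differs from compound 3 by isopropoxy in place of (4-chlorophenyl)sulfanyl on an aromatic carbon. Among the measured compounds shown here, two measured steps bear on this change: a 3.2-fold higher number from compound 2 to compound 3 (0.50 log units; beyond the scatter), in which methyl on the sulfur went with the lower number, and a 2.7-fold lower number from compound 1 to compound 2 (0.43 log units; beyond the scatter), in which methylsulfanyl gave the lowest number of the set. Since compound 4 again carries a group of four heavy atoms at this position, a modest step toward a lower number is expected, a 2.1-fold lower number from compound 3 to compound 4 (0.32 log units; beyond the scatter). Compound 4 is therefore estimated at 9 nM, with a range from 3 nM to 27 nM.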

Compound 4, half-maximal inhibitory concentration: 19 nM
Beside the measured number, compound 4's estimate is 2.1-fold (0.32 log units) below it; the range from low to high includes it.
By their numbers in this assay, from the lowest: compound 2; then compounds 1, 3 and 4 (each within the scatter of the next).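

In this assay, isopropoxy in place of (4-chlorophenyl)sulfanyl gives no change at the digits printed from compound 3 to compound 4 (within the scatter), so at this position going from 8 heavy atoms with an aromatic ring to 4 with no ring does not separate the two compounds. Isopropoxy in place of furan-2-yl likewise gives a 1.2-fold higher number from compound 1 to compound 4 (0.07 log units; within the scatter), whereas isopropoxy in place of methylsulfanyl gives a 3.2-fold higher number from compound 2 to compound 4 (0.50 log units; beyond the scatter), leaving compound 2 alone apart from the other three. Nothing measured here offers an explanation for this. Going by these compounds, whether compound 2 stands apart through the sulfur on the ring or through its single methyl stays open; methoxy or ethylsulfanyl at this position would bear on that.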